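The source may report more compounds than this note shows. Statements on the series, on what has been measured and on what is new or still open speak of the compounds shown alone.

In a functional assay (trachea) with Cavia porcellus as the target (on this read-out lower numbers stand for an effect already at smaller amounts and higher numbers for an effect only at larger amounts of compound), compound 1 `C=CCCn1c(=O)c2[nH]cnc2n(CCC)c1=O` gives 200 nM, compound 2 `CCCn1c(=O)n(CCCO)c(=O)c2[nH]cnc21` gives 5100 nM and compound 3 `CCCn1c(=O)n(CCC(C)=O)c(=O)c2[nH]cnc21` gives 3500 nM. Compound 3 therefore stands level with the hydroxymethyl analogue, at a 1.5-fold lower number from compound 2 to compound 3 (0.16 log units; within the scatter), and well away from the vinyl analogue, at an 18-fold higher number from compound 1 to compound 3 (1.24 log units; beyond the scatter).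

Compound 4 `CCCn1c(=O)n(CCCCC(C)=O)c(=O)c2[nH]cnc21` is reached through 2-acetylethyl in place of acetyl on a saturated chain carbon, two bonds along the chain from an aromatic nitrogen: 2-acetylethyl in place of acetyl, on a saturated chain carbon, two bonds along the chain from an aromatic nitrogen. Within the data shown here, no measured step covers this kind of change, so the evidence is indirect. The large steps, a 26-fold higher number from compound 1 to compound 2 (1.41 log units; beyond the scatter) and an 18-fold higher number from compound 1 to compound 3 (1.24 log units; beyond the scatter), both involve the loss of vinyl, which does not occur here. The closest guide is the exchange of hydroxymethyl for acetyl, a 1.5-fold lower number from compound 2 to compound 3 (0.16 log units; within the scatter), and this gives no sign of a large shift. A small move to a lower number is tentatively expected in this assay, with nothing beyond the scatter. The estimated step is a 1.6-fold lower number from compound 3 to compound 4 (0.20 log units; within the scatter). For compound 4 the estimated value is 2200 nM, with an expected range of 700 nM to 7000 nM.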

Compound 4, half-maximal effective concentration: 60 nM
The estimate for compound 4 lay 37-fold (1.56 log units) above the measured number; measured number below the stated range.
By their numbers in this assay, from the lowest: compound 4; then compound 1; then compounds 3 and 2 (each within the scatter of the next).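

In this assay, among these compounds, this position proves far more sensitive to chain length than the earlier compounds showed: 2-acetylethyl in place of acetyl gives a 58-fold lower number from compound 3 to compound 4 (1.77 log units; beyond the scatter) and the same terminal acetyl is kept on both sides of that step. The step of 2-oxopropyl in place of hydroxy gives an 85-fold lower number from compound 2 to compound 4 (1.93 log units; beyond the scatter) and 2-acetylethyl in place of vinyl gives a 3.3-fold lower number from compound 1 to compound 4 (0.52 log units; beyond the scatter) so a chain bearing a carbonyl can go beyond the vinyl-ended chain of compound 1 and a low number here does not depend on vinyl. No measurement at hand explains the gain.

On these data alone, whether the gain comes from chain length alone or needs the terminal acetyl remains open. So does the outcome with a longer chain such as 4-acetylbutyl, or with an amine or a carboxylic acid at the chain end.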